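Nitro for bromo on the aryl of the beta-lactam series

The source may hold more compounds than are shown below. What is called first, only, known or untested is meant among the compounds shown, and "the series" means these compounds.

Measured in a functional assay on MCF7 cells (Homo sapiens) for antiproliferative activity, read by MTT assay, with stated times of 24 h and 72 h; on this read-out lower numbers stand for stronger inhibition and higher numbers for weaker inhibition:
compound 1, `COc1cc(N2C(=O)[C@@H](Oc3ccccc3)[C@H]2c2ccc(Br)cc2)cc(OC)c1OC`, 48000 nM
compound 2, `COc1cc(N2C(=O)[C@H](Oc3ccccc3)[C@H]2c2ccc(C#N)cc2)cc(OC)c1OC`, 168000 nM
compound 3, `COc1cc(N2C(=O)[C@@H](Oc3ccccc3)[C@H]2c2cccc([N+](=O)[O-])c2)cc(OC)c1OC`, 30000 nM

Compound 1 gives the second highest of the three numbers; compound 3 is nearest and compound 2 furthest, its value lying beyond the scatter from that of compound 1.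

Compound 4, `COc1cc(N2C(=O)[C@@H](Oc3ccccc3)[C@H]2c2ccc([N+](=O)[O-])cc2)cc(OC)c1OC`, differs from compound 1 by nitro in place of bromo on an aromatic carbon. Going by the values given here, the one step that bears on this is a 1.6-fold lower number from compound 1 to compound 3 (0.20 log units; within the scatter), which stayed within the scatter. A nitro group entering at another position of the same ring is therefore expected to move this assay little, if at all, from compound 1, with a 1.4-fold lower number from compound 1 to compound 4 (0.14 log units; within the scatter) as the expected step. Compound 4 is estimated at 35000 nM, in the range 15000 nM to 90000 nM.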

Compound 4, half-maximal inhibitory concentration: 63000 nM
Compound 4: the middle estimate sits 1.8-fold (0.26 log units) below what was measured; the range from low to high includes it.
By their numbers in this assay, from the lowest: compounds 3, 1 and 4 (each within the scatter of the next, the first and the last beyond it); then compound 2.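

In this assay nitro in place of bromo on the aromatic carbon leaves the read-out within the scatter (a 1.3-fold higher number from compound 1 to compound 4 (0.12 log units; within the scatter)), so 4-bromophenyl and 4-nitrophenyl cannot be told apart here. Where the nitro group sits does register, though modestly: 4-nitrophenyl in place of 3-nitrophenyl gives a step beyond the scatter (a 2.1-fold higher number from compound 3 to compound 4 (0.32 log units; beyond the scatter)).

Still open, from the compounds shown here alone, is how an amine or a carboxylic acid in place of bromo on that aromatic carbon would read on the same core. Nothing at hand accounts for the difference between the two nitro placements.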